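Thiophene for furan in a barely surviving compound

A few compounds are considered here, and "the series" means these few. Any claim that something is new, unique, unknown or untested is made for them only; others in the source may bear on it.

Measured so far in an ADME assay on cells (Hepatocyte, Mus musculus) for metabolic stability, with a stated time of 30 min; a higher number here means that more of the compound is left, a lower number that less of the compound is left 
- compound 1 `O=C(OC1CCC(CN2CCN(c3cc(=O)c4cc(C(F)(F)F)cc([N+](=O)[O-])c4s3)CC2)CC1)c1ccco1` gives 0.6% 
- compound 2 `Nc1cc(C(F)(F)F)cc2c(=O)cc(N3CCN(CC4CCCCC4)CC3)sc12` gives 69.4% 

Compound 1 holds the lower number of the pair (0.6%), and compound 2 holds the higher one (69.4%), with the gap between them lying beyond the scatter. Compound 3 `O=C(OC1CCC(CN2CCN(c3cc(=O)c4cc(C(F)(F)F)cc([N+](=O)[O-])c4s3)CC2)CC1)c1cccs1` keeps the structure of compound 1 but carries thiophen-2-yl in place of furan-2-yl on a carbonyl carbon. Among the measured compounds shown here, no measured pair shows this change on its own, so any expectation for it is uncertain. Compound 1 already has almost nothing left (0.6%), which leaves little room for a further fall. The expected step of a number 1.4 percentage points higher from compound 1 to compound 3 (within the scatter) is therefore small, slightly upward if anything, and not beyond the scatter. The estimated value expected for compound 3 (2%, range 0% to 12%) stays near the bottom of the scale.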

Compound 3, percent of the compound remaining: 1.8%
Compound 3: the middle estimate sits 0.2 percentage points above what was measured; low and high end bracket the measured number.
By their numbers in this assay, from the lowest: compounds 1 and 3 (each within the scatter of the next); then compound 2.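

In this assay, thiophen-2-yl in place of furan-2-yl on a carbonyl carbon gives a number 1.2 percentage points higher from compound 1 to compound 3 (within the scatter), so this exchange of one five-membered aromatic ring for another does not lift the compound away from the bottom of the scale. Like compound 1, compound 3 at 1.8% has almost nothing left, which shows that swapping the ring oxygen for a ring sulfur at this position is not enough to change the reading. Nothing available bears on why the two numbers stay together.

With both compounds so near the bottom of the scale, this pair cannot show whether the position matters at all. Still open, on these data alone, is whether a phenyl ring on this carbonyl carbon, or an amine nitrogen in place of the oxygen next to a carbonyl group, would leave more of the compound.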